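Swapping fluoro for methylsulfanyl on the aryl ether

The source may hold more compounds than are shown below. What is called first, only, known or untested is meant among the compounds shown, and "the series" means these compounds.

Of the compounds shown here, two sharing one core have been measured so far. Compound 1, `CNC[C@]1(O)Cc2ccccc2[C@@H]1Oc1ccccc1CO`, carries a hydroxymethyl group on the outer aromatic ring. In an in vitro assay on HEK293 cells for inhibition of sodium-dependent dopamine transporter (Homo sapiens) (on this read-out higher numbers stand for weaker inhibition and lower numbers for stronger inhibition), compound 1 gives only the limit > 10000 nM, which is not a number. Compound 2, `CNC[C@]1(O)Cc2ccccc2[C@@H]1Oc1ccccc1F`, carries fluoro at the same aromatic carbon, and in this assay compound 2 gives 4000 nM. Among the compounds with values here, this is the only numerical value in the set; the other result is a limit, as the limit of > 10000 nM in this assay, at which 1 of the 2 values shown sits, records. Within the data shown here, the one measured step, an at least 2.5-fold lower number from compound 1 to compound 2 (0.39 log units; beyond the scatter), is therefore known only as a minimum size.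

Compound 3, `CNC[C@]1(O)Cc2ccccc2[C@@H]1Oc1ccccc1SC`, differs from compound 2 by methylsulfanyl in place of fluoro on an aromatic carbon. Among the measured compounds shown here, no measured step involves methylsulfanyl, so the only guidance is that a change at this aromatic carbon moved the read-out by at least a modest amount in one case. With nothing pointing in a direction, compound 3 is expected to show a 1.3-fold higher number from compound 2 to compound 3 (0.10 log units; within the scatter). The estimate for compound 3 in this assay is 5000 nM, with a range from 1000 nM to 20000 nM.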

Compound 3, half-maximal inhibitory concentration: > 10000 nM
Compound 3: only a limit was reported; the forecaster's own chance of this, stated with the estimate: 30%; at least 2.0-fold (0.30 log units) between middle value and limit.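

Within the data shown here, at this aromatic carbon, the one measured step so far pointed from hydroxymethyl to fluoro, and the new step runs back the other way: putting methylsulfanyl in place of fluoro gives an at least 2.5-fold higher number from compound 2 to compound 3 (0.39 log units; beyond the scatter), which means weaker inhibition, and this figure is only a minimum size since the result for compound 3 is a limit and not a number. Of the three groups seen at this carbon, only fluoro gives a real number in this assay, while hydroxymethyl and methylsulfanyl both end at the same limit: the limit of > 10000 nM in this assay, at which 2 of the 3 values shown sit. The step from compound 1 to compound 3 cannot be read, since both results are limits, so hydroxymethyl and methylsulfanyl cannot be put in any order.

Still open, from the compounds shown here alone, is whether any other group at this aromatic carbon, such as chloro, methoxy or a plain hydrogen, would give a lower number than fluoro does. Also open, going by these compounds, is how far the results for hydroxymethyl and methylsulfanyl really lie past the limit, and whether fluoro would give a similar number on another carbon of the same ring.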